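The source may report more compounds than this note shows. Statements on the series, on what has been measured and on what is new or still open speak of the compounds shown alone.

Measured so far in a functional assay on A10 cells (Oryctolagus cuniculus) for binding affinity, with A10 (Rattus norvegicus) as the target; a higher number here means a weaker inhibitor, a lower number a stronger inhibitor:

- Compound 1 `Nc1ccc(S(=O)(=O)Nc2cccs2)cc1`: 69000 nM
- Compound 2 `CCCCCc1cc(NS(=O)(=O)c2ccc(N)cc2)on1`: > 32000 nM

Compound 2 stands at > 32000 nM in this assay, and this figure is a limit of the assay, not a number. It therefore gives only a bound for comparison. The evidence so far amounts to this: the limit of > 32000 nM in this assay, at which 1 of the 2 values shown sits.

Compound 3 `Nc1ccc(S(=O)(=O)Nc2cc(-c3ccccc3)no2)cc1` keeps the rest of compound 2 and changes a single group: phenyl in place of pentyl on an aromatic carbon. The phenyl group of compound 3 sits next to the ring nitrogen, where compound 2 carries its pentyl group.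

Among the compounds with values here, no two measured compounds differ in just one place, so no earlier step shows what a change of this kind does. The expectation is therefore a step no larger than the usual scatter, in neither direction. A weak reading is expected for compound 3 since compound 1 gives 69000 nM. In numbers, the expected change is a step that the limit leaves unreadable from compound 2 to compound 3. The estimated value for compound 3 is 45000 nM, with an expected range from 12000 nM to 150000 nM.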

Compound 3, half-maximal inhibitory concentration: > 32000 nM
Compound 3 gave a limit, no number; the forecaster's own chance of this, stated with the estimate: 45%; the middle value lies beyond the limit too.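

Compound 2 and compound 3 both end in a limit in this assay, not a number, so the step from pentyl to phenyl cannot be read. The compounds shown leave open whether this change alters the reading at all, and in which direction, with most values resting on one bound: the limit of > 32000 nM in this assay, at which 2 of the 3 values shown sit.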